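Ethyl for hydrogen on two regioisomeric pyrazole hydroxamates

This account rests on a few compounds, and the source may have more. Where it says the series, first, only, none or still open, it means among the compounds named here.

Compound 1 `Cc1cc(-c2ccc(F)cc2)nn1Cc1ccc(C(=O)NO)cc1`: 11400 nM
Compound 2 `Cc1cc(-c2ccc(F)cc2)n(Cc2ccc(C(=O)NO)cc2)n1`: 33000 nM
Compound 3 `CCCc1cc(-c2ccc(F)cc2)nn1Cc1ccc(C(=O)NO)cc1`: 15200 nM

Of the compounds shown here, three have been measured in a functional assay on A549 cells (Homo sapiens) for antiproliferative activity, read by MTT assay, with a stated time of 96 h; a lower number here means a stronger inhibitor of growth, a higher number a weaker inhibitor of growth. Compound 1 and compound 2 share the same atoms joined differently; the difference between the two cores is not broken down here. Compound 3 carries, relative to compound 1, the change (ethyl in place of hydrogen on a saturated chain carbon bound to an aromatic carbon), and this gave a 1.3-fold higher number from compound 1 to compound 3 (0.12 log units; within the scatter). Compound 2 gives the highest number of the three in this assay.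

Compound 4 `CCCc1cc(-c2ccc(F)cc2)n(Cc2ccc(C(=O)NO)cc2)n1` is not yet measured. It differs from compound 2 by ethyl in place of hydrogen on a saturated chain carbon bound to an aromatic carbon, the same change that was made from compound 1 to compound 3, at the same place. Because that change gave a 1.3-fold higher number from compound 1 to compound 3 (0.12 log units; within the scatter), compound 4 is expected to sit close to compound 2, with an estimated step of a 1.2-fold higher number from compound 2 to compound 4 (0.08 log units; within the scatter). Compound 4 is thus estimated at 40000 nM, within a range of 20000 nM to 80000 nM.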

Compound 4, concentration for 50% growth inhibition: 16000 nM
Compound 4: middle estimate off by 2.5-fold (0.40 log units), on the high side; the whole stated range lies above it.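

In this assay, ethyl in place of hydrogen on the core of compound 2 gave a 2.1-fold lower number from compound 2 to compound 4 (0.31 log units; beyond the scatter), a modest step. The same change did not carry over unchanged from one core to the other, as the two steps differ: the same change on two cores in this assay, a 1.3-fold higher number (0.12 log units; within the scatter) from compound 1 to compound 3 and a 2.1-fold lower number (0.31 log units; beyond the scatter) from compound 2 to compound 4, 2.8-fold (0.44 log units) apart, beyond the scatter of two such steps This shows that, for these two pairs, the outcome of the change depends on the core it is made on; it does not show the reason, and two cores give no rule for predicting a third.

The compounds shown carry only methyl and propyl at this place. Going by these compounds, how a longer chain, a branched chain such as isopropyl, or an amine on the chain would behave on either core remains open.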